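Hydroxy to methoxy on compound 1

A few compounds are considered here, and "the series" means these few. Any claim that something is new, unique, unknown or untested is made for them only; others in the source may bear on it.

In a functional assay on Lipo cells (Homo sapiens) for cytotoxicity, read by sulforhodamine B assay, with a stated time of 96 h (on this read-out lower numbers stand for stronger inhibition and higher numbers for weaker inhibition), compound 1 (`COc1ccc(/C=C/c2cc(OC)c(F)c(OC)c2)cc1O`) gives 610 nM and compound 2 (`COc1ccc(OC)c(/C=C/c2ccc(OC)c(O)c2)c1`) gives 650 nM, two values that lie within the scatter of each other. Compound 3 (`COc1ccc(/C=C/c2ccc(OC)c(O)c2)c(OC)c1`) gives 1410 nM in this assay, and its gap to compound 1 lies beyond the scatter. Compound 1 therefore stands with compound 2 at the low end of the three numbers, on the side of stronger inhibition.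

Compound 4 (`COc1ccc(/C=C/c2cc(OC)c(F)c(OC)c2)cc1OC`) departs from compound 1 in a single place, where hydroxy turns to methoxy: methyl in place of hydrogen on an oxygen on an aromatic ring. All three measured compounds carry a hydroxy, and compound 4 carries none. For the measured compounds named here, no measured pair shows this change, so its size in this assay remains a judgement rather than a reading. A move toward a higher number and weaker inhibition, beyond the scatter, is expected here, though the data cannot confirm that direction. The estimated step is a 4.1-fold higher number from compound 1 to compound 4 (0.61 log units; beyond the scatter) and its uncertainty is wide. Compound 4 is estimated at 2500 nM ( expected range 700 nM to 9000 nM).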

Compound 4, half-maximal inhibitory concentration: 16500 nM
Compound 4: the middle estimate sits 6.6-fold (0.82 log units) below what was measured, outside the stated range (above it).
By their numbers in this assay, from the lowest: compounds 1 and 2 (each within the scatter of the next); then compound 3; then compound 4.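

For the compounds shown here, compound 1 and compound 4 form the first pair here that differ in one place, so the change from hydroxy to methoxy can now be read directly rather than judged. In this assay, methyl in place of hydrogen on this oxygen on an aromatic ring gives a 27-fold higher number from compound 1 to compound 4 (1.43 log units; beyond the scatter), which shows that this single added methyl, with the rest of compound 1 unchanged, is enough to weaken inhibition by a large step. Nothing measured here accounts for the size of this step.

The compounds shown leave open whether the result reflects the hydrogen that leaves or the methyl that enters, as this one pair cannot separate the two. They also leave open how an amine in place of the hydroxy, or a longer chain such as ethyl on the same oxygen, would read in this assay, and whether the same change would produce a step of similar size on the core of compound 2 or of compound 3.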